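Ester Variation and Half-Life in Buffer

The compounds below may be only part of what the source reports. "The series", "measured", "known", "first", "only" and "open" are said of these compounds alone.

Three esters built on a shared core have been examined in a physicochemical assay for metabolic stability, in phosphate buffer, at pH 7.4; on this read-out lower numbers stand for a shorter-lived compound and higher numbers for a longer-lived compound. Compound 1 `Cc1cn([C@H]2CO[C@@H](COC(=O)C(C)(C)C)O2)c(=O)[nH]c1=O` gives 46.3 h. Compound 2 `Cc1cn([C@H]2CO[C@@H](COC(=O)C3CCCCC3)O2)c(=O)[nH]c1=O` gives 53.3 h in this assay, and compound 3 `CC(=O)OC[C@@H]1OC[C@H](n2cc(C)c(=O)[nH]c2=O)O1` gives 44.2 h. Compound 1 sits between the other two on these numbers, yet all three lie close together: a 1.2-fold higher number from compound 1 to compound 2 (0.06 log units; within the scatter), a 1.0-fold lower number from compound 1 to compound 3 (0.02 log units; within the scatter), and a 1.2-fold lower number from compound 2 to compound 3 (0.08 log units; within the scatter).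

The step to compound 4 `CCCCCCCC(=O)OC[C@@H]1OC[C@H](n2cc(C)c(=O)[nH]c2=O)O1` is heptyl in place of tert-butyl on a carbonyl carbon. Two of the measured steps replace the same tert-butyl at this carbonyl carbon, one with cyclohexyl and one with methyl, and neither moved the half-life beyond the scatter. Within the data shown here, no measured step introduces a chain as long as heptyl, so there is no direct guide for that group, but every ester so far, whatever sat on the carbonyl carbon, returned a number within the scatter of the others. Compound 4 is therefore expected to show no step beyond the scatter, a 1.0-fold lower number from compound 1 to compound 4 (0.00 log units; within the scatter). Compound 4 is estimated at 46 h in this assay, with a range from 30 h to 70 h.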

Compound 4, half-life: 54.2 h
Beside the measured number, compound 4's estimate is 1.2-fold (0.07 log units) below it; measured number inside the range.
By their numbers in this assay, from the lowest: compounds 3, 1, 2 and 4 (each within the scatter of the next).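

In this assay, among these compounds, heptyl in place of tert-butyl on a carbonyl carbon brings a chain of this length to the position for the first time, and the step remains within the scatter (see a 1.2-fold higher number from compound 1 to compound 4 (0.07 log units; within the scatter)). The same holds when compound 4 is set against the other two esters, with a 1.2-fold higher number from compound 3 to compound 4 (0.09 log units; within the scatter) and a 1.0-fold higher number from compound 2 to compound 4 (0.01 log units; within the scatter), so methyl, tert-butyl, cyclohexyl and heptyl are not told apart by this read-out in these four compounds. No measurement at hand bears on why the half-life stays so level across these groups.

What remains open is whether this level picture would last for a chain longer than heptyl, or for a chain carrying an amine or a carboxylic acid, since every group shown on this carbonyl carbon is built from carbon alone. All four compounds also share one core and differ only at this carbonyl carbon, so they leave open how a change elsewhere in the molecule, such as an amide in place of the ester oxygen, would read in this assay.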